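The source may report more compounds than this note shows. Statements on the series, on what has been measured and on what is new or still open speak of the compounds shown alone.

Compound 1 `O=C(c1ccc(OCCCN2CCN(C(=O)[C@H]3CCCN3)CC2)cc1)C1CC1` and compound 2 `N[C@H](CC1CCCCC1)C(=O)N1CCN(CCCOc2ccc(C(=O)C3CC3)cc2)CC1` share one core and differ only at a carbonyl carbon. In an assay for binding affinity to histamine H2 receptor (Homo sapiens) (a lower number here means a stronger inhibitor, a higher number a weaker inhibitor), compound 1 gives 53700 nM, and compound 2 gives 20400 nM, so that the exchange brings a 2.6-fold lower number from compound 1 to compound 2 (0.42 log units; beyond the scatter). Going by the values given here, of the two numbers known so far, compound 2 stands lowest. Compound 3 `NCCC(=O)N1CCN(CCCOc2ccc(C(=O)C3CC3)cc2)CC1` takes the next step from compound 2: 2-aminoethyl in place of 1-amino-2-cyclohexylethyl on a carbonyl carbon. Among the compounds with values here, the single measured step bears on this only loosely, since it concerns a different exchange at the same carbonyl carbon, and it was modest in size. Within the data shown here, no measured pair tests the loss of the six-membered non-aromatic ring directly. Therefore the step expected in this assay is estimated as a 2.2-fold higher number from compound 2 to compound 3 (0.34 log units; beyond the scatter) with wide uncertainty. The estimate for compound 3 in this assay is 45000 nM, within a range of 15000 nM to 140000 nM.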

Compound 3, inhibition constant: 100000 nM
The estimate for compound 3 lay 2.2-fold (0.35 log units) below the measured number, within the range that was stated.
By their numbers in this assay, from the lowest: compound 2; then compounds 1 and 3 (each within the scatter of the next).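

In this assay, 2-aminoethyl in place of 1-amino-2-cyclohexylethyl on this carbonyl carbon gives a 4.9-fold higher number from compound 2 to compound 3 (0.69 log units; beyond the scatter), so the group carrying the six-membered non-aromatic ring now stands apart from both smaller groups tested here. Those two smaller groups do not separate: 2-aminoethyl in place of pyrrolidin-2-yl gives a 1.9-fold higher number from compound 1 to compound 3 (0.27 log units; within the scatter), so at this position the open chain and the pyrrolidin-2-yl group cannot be told apart in this assay. No supporting evidence is available to explain why compound 2 stands apart.

On these data alone, the exchange from compound 2 to compound 3 removes the ring, part of the chain and the defined stereocentre together, so their separate contributions remain open. A phenyl ring in place of the six-membered non-aromatic ring, or the same cyclohexyl-bearing chain without its amine, would test which part of the group matters.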